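A Fluorine on the Phenyl Ring of Compound 2

The compounds below may be only part of what the source reports. "The series", "measured", "known", "first", "only" and "open" are said of these compounds alone.

Compound 1 `Cc1c(C(C)C)c(=O)on1C(=O)N1CCCCC1` gives 2 nM in an assay (strain Wistar) for inhibition of Hormone-sensitive lipase (Rattus norvegicus), read by spectrophotometry; a higher number here means a weaker inhibitor, a lower number a stronger inhibitor. Within the data shown here, compound 2 `Cc1c(C(C)C)c(=O)on1C(=O)N1CCC(c2ccccc2)CC1` gives 12 nM in this assay, the highest of the two numbers so far. Compound 3 `Cc1c(C(C)C)c(=O)on1C(=O)N1CCC(c2cccc(F)c2)CC1` differs from compound 2 by fluoro in place of hydrogen on an aromatic carbon. Among the measured compounds shown here, no measured step concerns a fluoro substitution; the only step known, a 6.0-fold higher number from compound 1 to compound 2 (0.78 log units; beyond the scatter), describes adding the phenyl itself and bears on this change only loosely. Nothing beyond the scatter is therefore expected in this assay for compound 3. Compound 3 is estimated to give 12 nM, between 5 nM and 30 nM, which is an expected no change at the digits printed from compound 2 to compound 3 (within the scatter).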

Compound 3, half-maximal inhibitory concentration: 12 nM
Compound 3: the middle estimate sits on the measured number at the digits printed; measured number inside the range.
By their numbers in this assay, from the lowest: compound 1; then compounds 2 and 3 (each within the scatter of the next).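

In this assay, among these compounds, fluoro on an aromatic carbon, meta to a large group, is the first change on this phenyl ring, and it leaves the number in place (no change at the digits printed from compound 2 to compound 3 (within the scatter)). The gap to the core of compound 1 therefore stays as it was with the plain phenyl (a 6.0-fold higher number from compound 1 to compound 3 (0.78 log units; beyond the scatter)). No measurement at hand explains why the fluoro makes no difference.

Going by these compounds, whether a larger group on this ring, such as methoxy, trifluoromethyl or an amine, would also leave the number in place remains open. So does the effect of fluoro elsewhere on the ring.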